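Solubility of three measured amides and one open methyl case

The source may hold more compounds than are shown below. What is called first, only, known or untested is meant among the compounds shown, and "the series" means these compounds.

compound 1 `O=C(Nc1ccc([N+](=O)[O-])cc1Cl)c1cc(F)ccc1O`: 3.3 ug/mL
compound 2 `O=C(Nc1ccc([N+](=O)[O-])cc1Cl)c1ccc(Cl)cc1O`: 1.1 ug/mL
compound 3 `COc1ccc(O)c(C(=O)Nc2ccc([N+](=O)[O-])cc2Cl)c1`: 2.1 ug/mL

In a physicochemical assay for solubility (a higher number here means a more soluble compound, a lower number a less soluble compound), compound 3 lies within the scatter of both compound 1 and compound 2. Compound 4 `Cc1ccc(O)c(C(=O)Nc2ccc([N+](=O)[O-])cc2Cl)c1` has methyl in place of methoxy on an aromatic carbon, para to a hydroxy group (methyl in place of methoxy on an aromatic carbon). Going by the values given here, one measured step bears on this carbon: a 1.6-fold lower number from compound 1 to compound 3 (0.20 log units; within the scatter), with methoxy in place of fluoro. Among the compounds with values here, no measured compound yet shows how methyl behaves there. The expected change in this assay is a 1.1-fold lower number from compound 3 to compound 4 (0.02 log units; within the scatter), with no step beyond the scatter. The estimate for compound 4 is 2 ug/mL, within an expected range of 1 ug/mL to 4 ug/mL.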

Compound 4, solubility: < 1 ug/mL
Compound 4 gave a limit, no number; the forecaster's own chance of this, stated with the estimate: 5%; middle value at least 2.0-fold (0.30 log units) from the limit.
By their numbers in this assay, from the lowest: compounds 2, 3 and 1 (each within the scatter of the next, the first and the last beyond it). At a limit, below all of these: compound 4.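

At this carbon, para to a hydroxy group, this assay now shows steps beyond the scatter: methyl in place of methoxy gives an at least 2.1-fold lower number from compound 3 to compound 4 (0.32 log units; beyond the scatter), and methyl in place of fluoro gives an at least 3.3-fold lower number from compound 1 to compound 4 (0.51 log units; beyond the scatter). The earlier step at this carbon, between fluoro and methoxy, lay within the scatter. Compound 4 gave a limit and not a number, so both new steps are minimum sizes: the limit of < 1 ug/mL in this assay, at which 1 of the 4 values shown sits.

The compounds shown leave open how far compound 4 lies past that limit. They also leave open how an amine, a carboxylic acid or a longer chain would read at this carbon.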